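The compounds below may be only part of what the source reports. "The series", "measured", "known", "first", "only" and "open" are said of these compounds alone.

Measured so far:
- Compound 1, `N#C/C(=C\c1ccc(Cl)cc1)C(=O)c1ccc[nH]1`: 38000 nM
- Compound 2, `N#C/C(=C\c1c(F)c(F)c(F)c(F)c1F)C(=O)c1ccc[nH]1`: a limit, > 100000 nM
- Compound 3, `COc1ccc(CNC(=O)/C(C#N)=C/c2ccco2)cc1`: 33000 nM

All three were tested in a functional assay on SMA cells (Homo sapiens) for inhibition, read by MTT assay, with a stated time of 72 h; on this read-out higher numbers stand for weaker inhibition of growth and lower numbers for stronger inhibition of growth. Of the two numbers measured, the number for compound 3 is the one that sits at the low end, yet compound 3 and compound 1 lie within the scatter of each other, so no real difference between them can be read. The value of compound 2 is a limit of the assay and not a number; the bound reached there is the limit of > 100000 nM in this assay, at which 1 of the 3 values shown sits.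

Compound 4, `COc1ccc(CNC(=O)/C(C#N)=C/c2cc(Br)co2)cc1`, is compound 3 with one change: bromo in place of hydrogen on an aromatic carbon of the five-membered ring, reading furan-2-yl to 4-bromofuran-2-yl. Going by the values given here, no pair of measured compounds shows what such a change does in this assay, so the step from compound 3 is expected to be modest and in no sure direction, most likely none beyond the scatter. Compound 4 is therefore estimated at 25000 nM, with a range from 8000 nM to 80000 nM. This estimate means a step of a 1.3-fold lower number from compound 3 to compound 4 (0.12 log units; within the scatter).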

Compound 4, concentration for 50% growth inhibition: > 100000 nM
Compound 4 gave a limit, no number; the forecaster's own chance of this, stated with the estimate: 10%; middle value at least 4.0-fold (0.60 log units) away from the limit.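

In this assay, going by these compounds alone, this is the first change at a single place that can be read, and the step is beyond the scatter: bromo in place of hydrogen on this aromatic carbon gives an at least 3.0-fold higher number from compound 3 to compound 4 (0.48 log units; beyond the scatter). A higher number here means weaker inhibition of growth, so this carbon of the five-membered ring, two ring bonds from the ring oxygen, is not indifferent to substitution, and one added bromine atom is enough to show it. The value of compound 4, > 100000 nM, is a limit of the assay and not a number, and it is not the only such limit among the values: the limit of > 100000 nM in this assay, at which 2 of the 4 values shown sit.

From the compounds shown here alone, whether a fluoro group, a methyl group or an amine at this carbon would weaken inhibition of growth in the same way remains open. This single pair also cannot show whether bromo would have the same effect on the other carbons of the ring.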